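The source may hold more compounds than are shown below. What is called first, only, known or untested is meant among the compounds shown, and "the series" means these compounds.

Compound 3 `COc1ccc(/C(=C(/CCNC(=O)NCc2ccccc2)c2ccccc2)c2ccccc2)cc1` is one of three measured compounds built on a shared core. In a functional assay on MCF7 cells (Homo sapiens) for cytotoxicity, read by MTT assay, with a stated time of 72 h (on this read-out lower numbers stand for stronger inhibition and higher numbers for weaker inhibition), compound 3 gives > 50000 nM, which is a limit of the assay rather than a number. Compound 1 `COc1ccc(/C(=C(/CCCl)c2ccccc2)c2ccccc2)cc1` gives > 50000 nM, also a limit. Compound 2 `COc1ccc(/C(=C(/CCN)c2ccccc2)c2ccccc2)cc1` gives 16900 nM. For the measured compounds named here, the only readable step into compound 3 is an at least 2.9-fold higher number from compound 2 to compound 3 (0.47 log units; beyond the scatter). Compound 4 `COc1ccc(/C(=C(/CCNC(=O)N2CCOCC2)c2ccccc2)c2ccccc2)cc1` differs from compound 3 by morpholin-4-yl in place of benzylamino on a carbonyl carbon. Going by the values given here, no measured step alters this end of the chain in a comparable way, and two of the three values sit at the limit (the limit of > 50000 nM in this assay, at which 2 of the 3 values shown sit). Compound 4 is therefore expected to stay close to compound 3, with an estimated step of an at least 1.2-fold lower number from compound 3 to compound 4 (0.09 log units; that floor lies within the scatter). Compound 4 is estimated at 40000 nM, with a range from 12000 nM to 120000 nM.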

Compound 4, half-maximal inhibitory concentration: > 50000 nM
Compound 4 was reported as a limit (the forecaster's own chance of this, stated with the estimate: 60%); middle value at least 1.2-fold (0.09 log units) away from the limit.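

Placing (morpholin-4-yl)carbonyl on the amine nitrogen in this assay brings an at least 2.9-fold higher number from compound 2 to compound 4 (0.47 log units; beyond the scatter). The higher number seen with benzylcarbamoyl in compound 3 therefore also appears with a second group at this nitrogen, one that carries no aromatic ring. The steps among compound 1, compound 3 and compound 4 cannot be read, since all three values are limits: the limit of > 50000 nM in this assay, at which 3 of the 4 values shown sit.

Which of benzylamino and morpholin-4-yl gives the lower number stays open. From the compounds shown here alone, compound 2 stands at 16900 nM, and whether a dimethylamino group or a longer chain carrying the amine would lower that number is also open.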